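A Longer Chain on an Inactive Compound

This account rests on a few compounds, and the source may have more. Where it says the series, first, only, none or still open, it means among the compounds named here.

So far three compounds built on one shared core have been tested in a functional assay on IMR-32 cells (Homo sapiens) for antiproliferative activity, read by MTT assay; a lower number here means a stronger inhibitor, a higher number a weaker inhibitor. Compound 1 (`CC(=O)c1ccc(-n2cc(COc3ccc(/C=C/C(=O)c4ccc5c(c4O)CCC(C)(C)O5)cc3)nn2)cc1`) gives 89600 nM as the only numerical result in the set. Compound 2 (`CCc1ccccc1-n1cc(COc2ccc(/C=C/C(=O)c3ccc4c(c3O)CCC(C)(C)O4)cc2)nn1`) is reported as "not active" (no number reported) with no figure attached. Compound 3 (`CCCCCn1cc(COc2ccc(/C=C/C(=O)c3ccc4c(c3O)CCC(C)(C)O4)cc2)nn1`) is likewise reported as "not active" (no number reported) with no figure attached. Compound 3 therefore has no single number and shares that standing with compound 2, so neither can be placed numerically against compound 1.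

Compound 4 (`CCCCCCCCn1cc(COc2ccc(/C=C/C(=O)c3ccc4c(c3O)CCC(C)(C)O4)cc2)nn1`) is the next to be read. The structural change propyl in place of hydrogen on a saturated chain carbon, five bonds along the chain from an aromatic nitrogen puts propyl in place of hydrogen on a saturated chain carbon, five bonds along the chain from an aromatic nitrogen. For the measured compounds named here, no measured pair in the set shows what a change of this kind does. A large gain in strength is therefore not expected in this assay, and no step beyond the usual scatter is foreseen. Compound 4 may again be reported without a number, and any figure is expected to lie near the weak result of compound 1 at 89600 nM in this series. For compound 4 the estimated half-maximal inhibitory concentration is 80000 nM with an expected range from 30000 nM to 200000 nM if a number is obtained.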

Compound 4, half-maximal inhibitory concentration: "not active" (no number reported)
No number was reported for compound 4, and the estimate cannot be compared.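

In this assay, for the compounds shown here, compound 3 and compound 4 are both reported as not active, with no number for either, so the change from hydrogen to propyl gives no step that can be read. The compounds shown leave open whether any chain on the shared core gives a measurable figure in this assay at all. No available evidence bears on this result.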